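A few compounds are considered here, and "the series" means these few. Any claim that something is new, unique, unknown or untested is made for them only; others in the source may bear on it.

Measured so far:
Compound 1, `CCOC1=C(/C(C)=N/OCC(=O)Nc2ccc(Cl)c(C(F)(F)F)c2)N(C)S(=O)(=O)c2ccccc21` — in a functional assay on THP-1 cells (Homo sapiens) for inhibition, read by ELISA, with stated times of 2 h and 48 h (a lower number here means a stronger inhibitor, a higher number a weaker inhibitor), compound 1 gives > 20000 nM, a limit of the assay rather than a number.
Compound 2, `C/C(=N\OCC(=O)Nc1ccc(C(F)(F)F)cc1)C1=C(O)c2ccccc2S(=O)(=O)N1C` — in this assay compound 2 gives > 20000 nM, again a limit rather than a number.

Compound 2 therefore cannot be placed on a scale: its value is a limit. Both values shown so far sit at that same point, (the limit of > 20000 nM in this assay, at which 2 of the 2 values shown sit). For the measured compounds named here, no step between two measured numbers is available in this set. Compound 3, `C/C(=N\OCC(=O)Nc1ccc(Cl)c(C(F)(F)F)c1)C1=C(O)c2ccccc2S(=O)(=O)N1C`, differs from compound 2 in one place: 4-chloro-3-(trifluoromethyl)phenyl in place of 4-(trifluoromethyl)phenyl on an amide-type nitrogen. Going by the values given here, with every value so far at the limit, no movement beyond the usual scatter is expected for this change; the step from compound 2 to compound 3 is expected to be a number no higher from compound 2 to compound 3 (the limit leaves the size open), nothing more than scatter. Compound 3 is estimated at 20000 nM, within 8000 nM to 50000 nM, and the most likely outcome is another limit in this assay.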

Compound 3, half-maximal inhibitory concentration: > 20000 nM
Compound 3 gave a limit, no number (the forecaster's own chance of this, stated with the estimate: 75%); the middle value lies on the limit itself.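

No step can be read among compound 1, compound 2 and compound 3, since each stands at a limit in this assay: the limit of > 20000 nM in this assay, at which 3 of the 3 values shown sit.

The compounds shown leave open whether 4-chloro-3-(trifluoromethyl)phenyl or the ethyl on oxygen changes inhibition at all, and what in this series would give a readable number.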